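Cytotoxicity at the assay limit: from compound 2 to compound 4

A few compounds are considered here, and "the series" means these few. Any claim that something is new, unique, unknown or untested is made for them only; others in the source may bear on it.

Compound 1 `Fc1cccc(F)c1NC(=S)N/N=C\c1c[nH]c2ccccc12`: in an ADME assay on KB cells (Homo sapiens) for cytotoxicity, read by MTT assay, with a stated time of 44 h (on this read-out lower numbers stand for stronger inhibition and higher numbers for weaker inhibition), compound 1 gives > 100000 nM, which is a limit of the assay and not a number.
Compound 2 `Cc1ccccc1NC(=S)N/N=C\c1c[nH]c2ccccc12`: in this assay compound 2 gives > 100000 nM, again a limit and not a number.
Compound 3 `CN(Cc1ccccc1)C(=S)N/N=C\c1c[nH]c2ccccc12`: in this assay compound 3 gives > 100000 nM, also a limit and not a number.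

Compound 2 therefore stands nowhere in particular within the set: all three measured compounds sit together at the limit, and none can be ordered against another, because of the limit of > 100000 nM in this assay, at which 3 of the 3 values shown sit. Going by the values given here, no step between two measured compounds is available, so the data give no direction at all for a structural change on this part of the molecule.

Compound 4 `CC(C)CNC(=S)N/N=C\c1c[nH]c2ccccc12` differs from compound 2 in one place: isobutyl in place of 2-methylphenyl on an amide-type nitrogen. With every measured value sitting at the limit, the step from compound 2 to compound 4 is expected to be none beyond the scatter, a step that the limit leaves unreadable from compound 2 to compound 4. Compound 4 is accordingly expected to give 150000 nM in this assay, with a range from 50000 nM to 500000 nM, and most likely the assay will again report only a limit for compound 4.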

Compound 4, half-maximal inhibitory concentration: > 100000 nM
Compound 4: only a limit was reported; the forecaster's own chance of this, stated with the estimate: 85%; the middle value does not contradict the limit.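

No new step can be read from compound 2 to compound 4, because both values are limits and not numbers: (the limit of > 100000 nM in this assay, at which 4 of the 4 values shown sit). In this assay the compounds shown leave open whether any group on this amide-type nitrogen would give a readable value.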